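Cyclopropyl for Phenyl: Expecting Compound 3

This account rests on a few compounds, and the source may have more. Where it says the series, first, only, none or still open, it means among the compounds named here.

Compound 1 `OC(Cc1ccccc1)c1cc(Br)cc2[nH]ncc12`: 90%
Compound 2 `OC(Cc1ccccc1)c1cc(-c2ccccc2)cc2[nH]ncc12`: 4%

In an assay for inhibition of Indoleamine 2,3-dioxygenase 1 (Homo sapiens), read by spectrophotometry, with a stated time of 30 min, tested at 10 uM (a lower number here means less inhibition, a higher number more inhibition at the concentration tested (going by the name of the read-out)), compound 2 stands lowest of the two numbers measured, with compound 1 above it. Going by the values given here, the one measured step, a number 86 percentage points lower from compound 1 to compound 2 (beyond the scatter), is large and beyond the scatter. Compound 3 `OC(Cc1ccccc1)c1cc(C2CC2)cc2[nH]ncc12` differs from compound 2 by cyclopropyl in place of phenyl on an aromatic carbon. Among the compounds with values here, no measured step involves cyclopropyl, so the estimate rests only on the fact that the drop came with the phenyl now being removed. Compound 3 is therefore expected to recover part of that loss, an upward step a number 46 percentage points higher from compound 2 to compound 3 (beyond the scatter), estimated at 50% with a range of 15% to 85%.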

Compound 3, a percentage reported as inhibition, at one concentration (the size of the read-out at that concentration, not a potency): 62%
Compound 3: middle estimate off by 12 percentage points, on the low side; the range from low to high includes it.
By their numbers in this assay, from the lowest: compound 2; then compound 3; then compound 1.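

In this assay, the collapse seen with phenyl proves not to apply to every carbon group at this position: cyclopropyl in place of phenyl brings a number 58 percentage points higher from compound 2 to compound 3 (beyond the scatter). Bromo is still not matched, however, with cyclopropyl in its place giving a number 28 percentage points lower from compound 1 to compound 3 (beyond the scatter). Nothing available explains either step. Still open, as far as these compounds go, is whether an amine, a methyl group or a longer chain at this aromatic carbon would match bromo or fall nearer phenyl. Also open, from the compounds shown here alone, is whether a four-membered or five-membered carbon ring would retain what cyclopropyl does.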